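The source may hold more compounds than are shown below. What is called first, only, known or untested is meant among the compounds shown, and "the series" means these compounds.

Compound 1 `O=[N+]([O-])c1cccc(/N=N/N2CCCC2)c1`: 42000 nM. Compound 2 `Clc1ccc(/N=N/N2CCCCC2)cc1`: > 100000 nM, a limit of the assay rather than a number.

Among the measured compounds shown here, in an ADME assay on BHK-21 cells (Mesocricetus auratus) for cytotoxicity, read by MTT assay, with a stated time of 96 h (on this read-out lower numbers stand for higher toxicity in this test and higher numbers for lower toxicity in this test), compound 1 gives 42000 nM, the only plain number among the two measured compounds. Compound 2 reaches > 100000 nM, which is a limit of the assay and not a number; it sits at the limit of > 100000 nM in this assay, at which 1 of the 2 values shown sits. Compound 3 `c1ccc(/N=N/N2CCCC2)cc1` is not yet measured and differs from compound 1 by hydrogen in place of nitro on an aromatic carbon. For the measured compounds named here, no measured pair shows this change, so the step is expected to be modest in this assay, toward lower toxicity, and could remain within the scatter. Compound 3 is expected at 80000 nM, between 30000 nM and 200000 nM, a step of a 1.9-fold higher number from compound 1 to compound 3 (0.28 log units; within the scatter).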

Compound 3, half-maximal cytotoxic concentration: >= 100000 nM
Compound 3: no number, only a limit (the forecaster's own chance of this, stated with the estimate: 40%); at least 1.2-fold (0.09 log units) between middle value and limit.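

In this assay, hydrogen in place of nitro on the aromatic carbon gives an at least 2.3-fold higher number from compound 1 to compound 3 (0.37 log units; beyond the scatter), so this is the first single change shown to move the read-out beyond the usual scatter, toward lower toxicity in this test. The true size of the step remains unknown, since compound 3 has a limit of the assay and not a number: the limit of >= 100000 nM in this assay, at which 1 of the 3 values shown sits.

As far as these compounds go, whether an amine or a carboxylic acid on the same aromatic carbon would behave like nitro or like hydrogen stays open. Compound 2 differs from compound 3 in more than one place, so it cannot settle this.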